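This account rests on a few compounds, and the source may have more. Where it says the series, first, only, none or still open, it means among the compounds named here.

In a functional assay on MCF7 cells (Homo sapiens) for inhibition, read by MTT assay (on this read-out lower numbers stand for stronger inhibition and higher numbers for weaker inhibition), compound 1 `O=C(CCCCCCC(=O)Nc1nnc(-c2ccco2)s1)NO` gives 880 nM and compound 2 `Cc1ccc(-c2nnc(NC(=O)CCCCCCC(=O)NO)s2)o1` gives 880 nM, so compound 2 stands level with compound 1, its nearest neighbour. Compound 3 `O=C(CCCCCCC(=O)Nc1nnc(-c2cccs2)s1)NO` is still unmeasured. The change is thiophen-2-yl in place of 5-methylfuran-2-yl on an aromatic carbon. For the measured compounds named here, one measured step bears on it: no change at the digits printed from compound 1 to compound 2 (within the scatter), methyl in place of hydrogen on an aromatic carbon. That step covers only the loss or gain of the methyl. Going by the values given here, no measured step covers the exchange of the ring oxygen for sulfur, so the data give no direction, and no step beyond the scatter is expected in this assay. The expected step is a 1.0-fold higher number from compound 2 to compound 3 (0.01 log units; within the scatter). For compound 3 the estimated value is 900 nM, with an expected range of 350 nM to 2200 nM.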

Compound 3, half-maximal inhibitory concentration: 880 nM
Compound 3: middle estimate off by 1.0-fold (0.01 log units), on the high side; measured number inside the range.
By their numbers in this assay, from the lowest: compounds 1, 2 and 3 (each within the scatter of the next).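

In this assay, thiophen-2-yl in place of 5-methylfuran-2-yl reads as no change at the digits printed from compound 2 to compound 3 (within the scatter), and thiophen-2-yl in place of furan-2-yl reads as no change at the digits printed from compound 1 to compound 3 (within the scatter). The earlier pair covered only the methyl; these steps add that, on this aromatic carbon of the shared core, a five-membered aromatic ring with sulfur as its hetero atom reads the same as one with oxygen, with or without the methyl on the furan. Nothing available accounts for this flat reading.

From the compounds shown here alone, all three compounds carry a five-membered aromatic ring with 1 hetero atom here, so the effect of a phenyl group or an amine at this position stays open. Also open, going by these compounds, are 5-methylthiophen-2-yl and a longer chain on the shared core.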